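A few compounds are considered here, and "the series" means these few. Any claim that something is new, unique, unknown or untested is made for them only; others in the source may bear on it.

Compound 1 `CC1(C)C[C@@H](CN([C@H](CCC(F)(F)F)C(N)=O)S(=O)(=O)c2ccc(Cl)cc2)O1`: 3.8
Compound 2 `CC1(C)CO[C@H]1CN([C@H](CCC(F)(F)F)C(N)=O)S(=O)(=O)c1ccc(Cl)cc1`: 3.8
Compound 3 `NC(=O)[C@@H](CCC(F)(F)F)N(CC1CCCC1)S(=O)(=O)c1ccc(Cl)cc1`: 5.15

In a physicochemical assay for lipophilicity, read by HPLC, measured as octanol-water partition, at pH 7.4 (a lower number here means a more polar compound, a higher number a more lipophilic compound), compound 1 stands level with compound 2, the two together the lowest of the three numbers, with no change at the digits printed from compound 1 to compound 2 (within the scatter). Its furthest neighbour is compound 3, with a number 1.35 log units higher from compound 1 to compound 3 (beyond the scatter). Compound 4 `NC(=O)[C@@H](CCC(F)(F)F)N(C[C@H]1CCCCO1)S(=O)(=O)c1ccc(Cl)cc1` differs from compound 1 by oxan-2-yl in place of 4,4-dimethyloxetan-2-yl on a saturated chain carbon bound to a sulfonamide nitrogen. Among the compounds with values here, two measured steps bear on this change: a number 1.35 log units higher from compound 1 to compound 3 (beyond the scatter) and a number 1.35 log units higher from compound 2 to compound 3 (beyond the scatter), both large, both where cyclopentyl replaces a dimethyloxetanyl ring. In compound 4 the ring oxygen and the hydrogen-bond acceptor are kept and only the ring size and the gem-dimethyl change, so a much smaller step in this assay is expected, upward if any. Compound 4 is therefore estimated at 4, between 3.6 and 4.4, a step of a number 0.20 log units higher from compound 1 to compound 4 (within the scatter) that is expected to lie near the scatter.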

Compound 4, distribution coefficient: 4.3
Estimate against measurement, compound 4: 0.30 log units below, and the stated range covers the measured number.
By their numbers in this assay, from the lowest: compounds 1 and 2 (each within the scatter of the next); then compound 4; then compound 3.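

In this assay, oxan-2-yl in place of 4,4-dimethyloxetan-2-yl gives a number 0.50 log units higher from compound 1 to compound 4 (beyond the scatter) even though the two groups have the same count of heavy atoms and hydrogen-bond acceptors, and the change from the other oxetane gives a number 0.50 log units higher from compound 2 to compound 4 (beyond the scatter) while the two oxetanes themselves stood level. Replacing cyclopentyl with oxan-2-yl gives a number 0.85 log units lower from compound 3 to compound 4 (beyond the scatter) and so places compound 4 in the gap between the oxetanes and the carbocycle. No supporting evidence accounts for these steps. The compounds shown leave open where oxolan-2-yl, an open-chain methoxyethyl group or an amine such as piperidin-2-yl would fall on a saturated chain carbon bound to a sulfonamide nitrogen.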